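Swapping ethylsulfanyl for carbamoyl on a small antiproliferative series

The source may report more compounds than this note shows. Statements on the series, on what has been measured and on what is new or still open speak of the compounds shown alone.

In a functional assay on HeLa cells (Homo sapiens) for antiproliferative activity, read by CCK-8 assay, with a stated time of 72 h (a higher number here means a weaker inhibitor, a lower number a stronger inhibitor), compound 1 `COc1ccc(-c2cncnc2-c2cc(OC)c(OC)c(OC)c2)cc1` gives 1140 nM, and compound 2 `CCOC(=O)Oc1cc(-c2cncnc2-c2cc(OC)c(OC)c(OC)c2)ccc1OC` gives 650 nM. Compound 3 `CCSc1ccc(-c2cncnc2-c2cc(OC)c(OC)c(OC)c2)cc1` gives 370 nM, which cannot be told apart from the value of compound 2 but stands clearly under that of compound 1.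

Compound 4 `COc1cc(-c2ncncc2-c2ccc(C(N)=O)cc2)cc(OC)c1OC` differs from compound 3 as follows: carbamoyl in place of ethylsulfanyl on an aromatic carbon. Carbamoyl thus takes the place of ethylsulfanyl on an aromatic carbon, para to a large group.

Among the measured compounds shown here, two measured steps bear on this. The closer one changes the group at this same place, and it is modest: a 3.1-fold lower number from compound 1 to compound 3 (0.49 log units; beyond the scatter). The other changes a different place and shows a 1.8-fold lower number from compound 1 to compound 2 (0.24 log units; within the scatter). So the number does respond to the group at this place, but no compound measured so far carries carbamoyl, which leaves the size of the step uncertain.

The expected change is a move toward weaker inhibition, and the estimated step is a 5.4-fold higher number from compound 3 to compound 4 (0.73 log units; beyond the scatter). For compound 4 the estimated value is 2000 nM, with an expected range of 600 nM to 8000 nM.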

Compound 4, half-maximal inhibitory concentration: > 100000 nM
Compound 4 gave a limit, no number (the forecaster's own chance of this, stated with the estimate: 10%); at least 50-fold (1.69 log units) between middle value and limit.
By their numbers in this assay, from the lowest: compounds 3, 2 and 1 (each within the scatter of the next, the first and the last beyond it). At a limit, above all of these: compound 4.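

In this assay, compound 4 reads only as a limit, not a number: the limit of > 100000 nM in this assay, at which 1 of the 4 values shown sits. Even so, it shows that this position tolerates far less than the earlier compounds suggested, with an at least 270-fold higher number from compound 3 to compound 4 (2.43 log units; beyond the scatter) and an at least 87-fold higher number from compound 1 to compound 4 (1.94 log units; beyond the scatter). Ethylsulfanyl and carbamoyl have the same heavy-atom count, so that count alone does not track the loss of activity, while carbamoyl also brings a hydrogen-bond donor and a double bond outside the aromatic rings.

Which of these differences matters cannot be told from a single swap, and it remains open whether the loss belongs to carbamoyl alone or extends to a carboxylic acid, a nitrile or an amine at this place. A longer chain such as propylsulfanyl also remains untested among the compounds shown.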